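Hydroxy to methoxy on the shared core

This account rests on a few compounds, and the source may have more. Where it says the series, first, only, none or still open, it means among the compounds named here.

Compound 1 `COc1cc(C(c2cc(OC)c(OC)c(OC)c2)[C@@H]2COC(=O)[C@H]2C)cc(OC)c1O` and compound 2 `COc1cc(C(c2cc(OC)c(OC)c(OC)c2)[C@@H]2COC(=O)[C@H]2C)cc(O)c1OC` share one core and differ only in which aromatic oxygen carries the free hydrogen. In a functional assay on HepG2 cells (Homo sapiens) for cytotoxicity (on this read-out higher numbers stand for weaker inhibition and lower numbers for stronger inhibition), compound 1 gives 163000 nM. For compound 2 the result in this assay is a limit of the assay, > 231000 nM. Compound 2 therefore stands at the limit of > 231000 nM in this assay, at which 1 of the 2 values shown sits, and has no number of its own; of compound 1 and compound 2 only their two values can be stated, not an order. Compound 3 `COc1cc(C(c2cc(OC)c(OC)c(OC)c2)[C@@H]2COC(=O)[C@H]2C)cc(OC)c1OC` has not been measured. It differs from compound 2 by methyl in place of hydrogen on an oxygen on an aromatic ring. For the measured compounds named here, no measured pair sets the size of such a step. With compound 2 known only as a limit, the expected step is a number no higher from compound 2 to compound 3 (the limit leaves the size open), that is none beyond the scatter in either direction. Compound 3 is estimated to give 230000 nM in this assay, within 110000 nM to 460000 nM, with a fair chance that only a limit is reported.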

Compound 3, half-maximal inhibitory concentration: 189000 nM
Compound 3: middle estimate off by 1.2-fold (0.09 log units), on the high side; low and high end bracket the measured number.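

The change from hydroxy to methoxy on an oxygen on an aromatic ring now has a measured number at both ends: in this assay it reads a 1.2-fold higher number from compound 1 to compound 3 (0.06 log units; within the scatter), so at this place on the shared core it shows no change beyond the scatter. The same change read on the other oxygen gives an at least 1.2-fold lower number from compound 2 to compound 3 (0.08 log units; that floor lies within the scatter), which fixes only a floor for the step and leaves its full size unknown. The value for compound 2 remains a limit of the assay: the limit of > 231000 nM in this assay, at which 1 of the 3 values shown sits.

Still open, on these data alone, is whether a longer chain on this oxygen, such as ethyl or a chain ending in an amine, would move the number beyond the scatter. Also open, as far as these compounds go, is whether a carboxylic acid elsewhere on the shared core would do so.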